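The compounds below may be only part of what the source reports. "The series", "measured", "known", "first", "only" and "open" are said of these compounds alone.

Measured so far:
Compound 1, `COC(=O)c1cc(-c2cccc(NC(=O)c3ccc(/C=C/C(=O)c4cccc(Cl)c4)cc3)c2)on1`: in an ADME assay on Vero cells (Chlorocebus sabaeus) for cytotoxicity, read by MTT assay, with a stated time of 72 h (a higher number here means that more compound is tolerated, a lower number that less compound is tolerated), compound 1 gives > 2.5 ug/mL, which is a limit of the assay.
Compound 2, `COC(=O)c1cc(-c2cccc(NC(=O)c3ccc(/C=C/C(=O)c4cccnc4)cc3)c2)on1`: in this assay compound 2 gives "not determined" (no result reported).
Compound 3, `COC(=O)c1cc(-c2cccc(NC(=O)c3ccc(/C=C/C(=O)c4cccc(C(F)(F)F)c4)cc3)c2)on1`: in this assay compound 3 gives > 20 ug/mL, also a limit.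

Compound 2 therefore stands nowhere on the numbers shown: no result is reported for it, and the two other values of the series are limits rather than numbers, so there is no measured starting point for the step. Compound 4, `COC(=O)c1cc(-c2cccc(NC(=O)c3ccc(/C=C/C(=O)c4ccc(C)c(F)c4)cc3)c2)on1`, differs from compound 2 in one place: 3-fluoro-4-methylphenyl in place of pyridin-3-yl on a carbonyl carbon. Among the compounds with values here, the only measured step, a step that the two limits leave unreadable from compound 1 to compound 3, is also a change of the aryl group on a carbonyl carbon, but its size cannot be read because both ends sit at limits, one at the limit of > 2.5 ug/mL in this assay, at which 1 of the 3 values shown sits, and the other at the limit of > 20 ug/mL in this assay, at which 1 of the 3 values shown sits. Within the data shown here, no measured step bears on the change from compound 2 to compound 4 with a readable size, and no direction can be drawn from the data; only that neither measured compound shows a number within the tested range.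

For compound 4 the expectation in this assay is therefore a value around 20 ug/mL, estimated to lie between 5 ug/mL and 60 ug/mL, with a fair chance that again only a limit is reported.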

Compound 4, half-maximal cytotoxic concentration: > 50 ug/mL
Compound 4 gave a limit, no number; the forecaster's own chance of this, stated with the estimate: 65%; middle value at least 2.5-fold (0.39 log units) from the limit.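

In this assay compound 4 gives > 50 ug/mL, which is a limit and not a number. The steps among compound 1, compound 3 and compound 4 cannot be read, as all three values are limits. The compounds shown leave open whether exchanging the aryl group on the carbonyl carbon shifts the tolerated concentration in this assay at all, and by how much.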